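The source may report more compounds than this note shows. Statements on the series, on what has been measured and on what is new or still open speak of the compounds shown alone.

Measured compounds:
compound 1, `Cn1c(=O)c(C(=O)Nc2ccccc2N)c(O)c2ccccc21`, 41.4%
compound 2, `Nc1ccccc1NC(=O)c1c(O)c2ccccc2n(-c2ccccc2)c1=O`, 34.7%
compound 3, `Cn1c(=O)c(C(=O)NCCCCCCNC(=O)CCCCC2CCSS2)c(O)c2ccccc21`, 38.8%

The three compounds were measured in a functional assay, with a stated time of 60 min, tested at 0.5 mM; a higher number here means a stronger effect of the compound at the concentration tested, a lower number a weaker effect. In this assay compound 1 gives 41.4%, compound 2 gives 34.7% and compound 3 gives 38.8%. All three values lie within the scatter of one another, so no order among them can be read.

Compound 1 and compound 2 differ in one place: phenyl in place of methyl on an aromatic nitrogen. The step of a number 6.7 percentage points lower from compound 1 to compound 2 (within the scatter) is within the scatter, so this change left the activity essentially unchanged in that pair.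

Compound 4, `O=C(CCCCC1CCSS1)NCCCCCCNC(=O)c1c(O)c2ccccc2n(-c2ccccc2)c1=O`, has not yet been measured. It stands to compound 3 as compound 2 stands to compound 1: phenyl in place of methyl on an aromatic nitrogen. The place of the change is the same in both pairs, so this is the same change. Among the measured compounds shown here, the difference between the core of compound 1 and that of compound 3 is not broken down here; what is known is only that compound 1 and compound 3 give values within the scatter of each other.

Because the step of a number 6.7 percentage points lower from compound 1 to compound 2 (within the scatter) was within the scatter, a step of similar size is expected from compound 3 to compound 4, namely a number 6.3 percentage points lower from compound 3 to compound 4 (within the scatter). For compound 4 the expected value in this assay is 32.5%, estimated to lie between 20% and 45%.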

Compound 4, a percentage reported as activity, at one concentration (the size of the read-out at that concentration, not a potency): 29.5%
Beside the measured number, compound 4's estimate is 3 percentage points above it; the measured number falls inside the stated range.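

Placing phenyl in place of methyl on the aromatic nitrogen of the core of compound 3 gave, in this assay, a number 9.3 percentage points lower from compound 3 to compound 4 (within the scatter). Set beside the earlier pair, the same change reads alike on the two cores, with no difference between the steps that can be told from the scatter: the same change on two cores in this assay, a number 6.7 percentage points lower (within the scatter) from compound 1 to compound 2 and a number 9.3 percentage points lower (within the scatter) from compound 3 to compound 4, 2.6 percentage points apart, within the scatter of two such steps. This shows that, in this assay and at its single tested concentration, the change carries from the core of compound 1 to the core of compound 3 without a detectable shift in its step, but both steps lie within the scatter, so the pairs do not establish that the change has any real effect on either core, and two pairs say nothing about how it would read on a further core.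

The compounds shown leave open how other groups on that aromatic nitrogen, such as ethyl or benzyl, would read in this assay. They also leave open whether the two steps would stay alike with a shorter or longer chain between the two amide groups, or with a carboxylic acid at the end of the chain.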